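Amide replacement in a small series

The compounds below may be only part of what the source reports. "The series", "measured", "known", "first", "only" and "open" are said of these compounds alone.

Measured in a functional assay (aorta) with Rattus norvegicus as the target; a higher number here means that more compound is needed for the effect, a lower number that less compound is needed:
- compound 1 `CNC(=N)Nc1nc(-c2ccc(OC)cc2)c(-c2ccc(OC)cc2)s1`: 1.2 uM
- compound 2 `COc1ccc(-c2nc(CN(C)C)sc2-c2ccc(OC)cc2)cc1`: 8.4 uM
- compound 3 `COc1ccc(-c2nc(C(=O)N(C)C)sc2-c2ccc(OC)cc2)cc1`: 3 uM

Compound 3 holds the middle place of the three numbers, with a 2.5-fold higher number from compound 1 to compound 3 (0.40 log units; beyond the scatter) and a 2.8-fold lower number from compound 2 to compound 3 (0.45 log units; beyond the scatter).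

Compound 4 `COc1ccc(-c2nc(C(=O)N3CCCCC3CCO)sc2-c2ccc(OC)cc2)cc1` is still unmeasured in this assay. It keeps the carbonyl and the shared core of compound 3, and the change is 2-(2-hydroxyethyl)piperidin-1-yl in place of dimethylamino on a carbonyl carbon, which puts 2-(2-hydroxyethyl)piperidin-1-yl in place of dimethylamino on a carbonyl carbon.

For the measured compounds named here, no measured step alters a group on that carbonyl carbon, so the three steps at hand bear on it only indirectly. All three are modest and exchange a whole group on an aromatic carbon, the largest being a 7.0-fold higher number from compound 1 to compound 2 (0.85 log units; beyond the scatter). They give no direction, and no step beyond the scatter is expected, though one of similar modest size in either direction would not be surprising.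

The estimated step is a 1.2-fold lower number from compound 3 to compound 4 (0.08 log units; within the scatter).

For compound 4 the expected value is 2.5 uM, with an estimated range of 0.7 uM to 9 uM.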

Compound 4, concentration for half-maximal effect: 6.8 uM
The estimate for compound 4 lay 2.7-fold (0.43 log units) below the measured number; measured number inside the range.
By their numbers in this assay, from the lowest: compound 1; then compound 3; then compounds 4 and 2 (each within the scatter of the next).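

For the compounds shown here, on the carbonyl carbon, the first measured change in this assay gives a 2.3-fold higher number from compound 3 to compound 4 (0.36 log units; beyond the scatter), with 2-(2-hydroxyethyl)piperidin-1-yl in place of dimethylamino. The step is modest, so a group with one six-membered non-aromatic ring, 1 hydrogen-bond donor and 1 hydrogen-bond acceptor still gives a measurable effect here, though more compound is needed than with dimethylamino. No supporting data on the compounds explain this step.

Going by these compounds, the ring and the 2-hydroxyethyl chain enter together, so the share of each in the step remains open. Plain piperidin-1-yl, a piperidine carrying an ethyl chain, or a morpholine on the same carbonyl carbon would help to separate these contributions.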